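Para-substituent variation on the benzyl group of the hydroxamate series

A few compounds are considered here, and "the series" means these few. Any claim that something is new, unique, unknown or untested is made for them only; others in the source may bear on it.

Three compounds share one core and differ only in the group on the benzyl ring. Compound 1 `O=C(CCC1=CCN(Cc2ccc(F)cc2)C1=O)NO` gives 6060 nM in a functional assay on NUGC-3 cells (Homo sapiens) for inhibition, read by sulforhodamine B assay; a higher number here means a weaker inhibitor of growth, a lower number a stronger inhibitor of growth. Compound 3 `O=C(CCC1=CCN(Cc2ccc(Cl)cc2)C1=O)NO` gives 4280 nM in this assay, and the step of a 1.4-fold lower number from compound 1 to compound 3 (0.15 log units; within the scatter) is within the scatter. Compound 2 `O=C(CCC1=CCN(Cc2ccc(Br)cc2)C1=O)NO` has no result in this assay, recorded as "not determined" (no result reported). On the two numbers shown, compound 3 holds the lowest one, with compound 1 nearest and within the scatter of it.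

Compound 4 `N#Cc1ccc(CN2CC=C(CCC(=O)NO)C2=O)cc1` differs from compound 3 as follows: cyano in place of chloro on an aromatic carbon. For the measured compounds named here, only the halogen-to-halogen step from compound 1 to compound 3 bears on this change, and it was within the scatter; no measured step covers a cyano group. No step beyond the scatter is therefore expected, and compound 4 is estimated at 4500 nM (range 1500 nM to 13000 nM) in this assay. The step from compound 3 is expected as a 1.1-fold higher number from compound 3 to compound 4 (0.02 log units; within the scatter), i.e. no clear change.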

Compound 4, concentration for 50% growth inhibition: > 10000 nM
Compound 4 ended at the assay's limit; the forecaster's own chance of this, stated with the estimate: 5%; middle value at least 2.2-fold (0.34 log units) from the limit.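

Compound 4 stands as a limit and not as a number: the limit of > 10000 nM in this assay, at which 1 of the 4 values shown sits. The change of group on this aromatic carbon now gives a step beyond the scatter, an at least 2.3-fold higher number from compound 3 to compound 4 (0.36 log units; beyond the scatter), which the halogen swap did not. Against the fluoro analogue, the step is only a floor, an at least 1.6-fold higher number from compound 1 to compound 4 (0.21 log units; that floor lies within the scatter), so that comparison stays unresolved.

As far as these compounds go, the true number for compound 4 remains open. Also open, from the compounds shown here alone, is whether an amine or a carboxylic acid on this aromatic carbon would stay close to compound 3 or move as the cyano group does.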